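A few compounds are considered here, and "the series" means these few. Any claim that something is new, unique, unknown or untested is made for them only; others in the source may bear on it.

Measured so far:
- compound 1 `Cc1ccc2nc(/N=C3\C(=O)N(CN4CCCCC4)c4cccc(Br)c43)sc2c1` — 85200 nM
- compound 2 `Cc1ccc2nc(/N=C3\C(=O)N(CN(C)C)c4cccc(Cl)c43)sc2c1` — 5770 nM

For the measured compounds named here, in an ADME assay on 184B5 cells (Homo sapiens) for cytotoxicity, read by sulforhodamine B assay, with a stated time of 48 h (on this read-out higher numbers stand for weaker inhibition of growth and lower numbers for stronger inhibition of growth), compound 2 stands at the lowest of the two numbers so far. Its nearest neighbour, compound 1, gives the higher number, and the gap between the two lies beyond the usual scatter of this assay.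

Compound 3 `Cc1ccc2nc(/N=C3\C(=O)N(CN4CCCCC4)c4cccc(Cl)c43)sc2c1` has not yet been measured. It differs from compound 2 in one place: piperidin-1-yl in place of dimethylamino on a saturated chain carbon bound to an amide-type nitrogen in a ring. Going by the values given here, no measured pair shows this change on its own, so the size of the step is not known. Compound 1 also carries the piperidin-1-yl group, but it differs from compound 3 in a second place as well, so its number is only a loose guide.

Because compound 1 with the same piperidin-1-yl group gives 85200 nM, the step is expected to run toward weaker inhibition of growth. The step from compound 2 to compound 3 is estimated at a 4.3-fold higher number from compound 2 to compound 3 (0.64 log units; beyond the scatter) in this assay. Compound 3 is expected to give about 25000 nM, within 8000 nM to 80000 nM.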

Compound 3, concentration for 50% growth inhibition: 82300 nM
The estimate for compound 3 lay 3.3-fold (0.52 log units) below the measured number, outside the stated range (above it).
By their numbers in this assay, from the lowest: compound 2; then compounds 3 and 1 (each within the scatter of the next).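

In this assay the change from dimethylamino to piperidin-1-yl, on a saturated chain carbon bound to an amide-type nitrogen in a ring, can now be read on its own, and it gives a 14-fold higher number from compound 2 to compound 3 (1.15 log units; beyond the scatter) as a large move toward weaker inhibition of growth. With piperidin-1-yl held in place, chloro in place of bromo on an aromatic carbon gives a 1.0-fold lower number from compound 1 to compound 3 (0.02 log units; within the scatter) and so leaves the read-out within the scatter, which makes the amine on the chain, and not this halogen swap, the change that moves the number among the single-place pairs shown. Nothing measured here accounts for the size of the amine step.

The compounds shown leave open whether the same amine step would be as large with bromo on the aromatic carbon, since dimethylamino appears only with chloro. They also leave open where other amines on this chain carbon would fall, such as pyrrolidin-1-yl, morpholin-4-yl or diethylamino, and so whether the large step follows the ring, its size or something else.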